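Urea series: chloro-methyl pyridine variant, expected outcome

The source may hold more compounds than are shown below. What is called first, only, known or untested is meant among the compounds shown, and "the series" means these compounds.

The series is read in a functional assay on CHO cells for antagonist activity at sphingosine 1-phosphate receptor 2 (Homo sapiens), read by scintillation counting and GTPgammaS binding, with a stated time of 4 h, in the presence of a further agent that is not named here; on this read-out lower numbers stand for stronger inhibition and higher numbers for weaker inhibition. Compound 1 `Cc1cc(CNC(=O)c2cc3c(Cl)cc(Cl)cc3[nH]2)ncc1-c1cn(C)nc1C` gives 0.61 nM. Among the compounds with values here, compound 2 `CCOc1cc(NC(=O)NCc2cc(C)c(-c3cn(C)nc3C(F)(F)F)nn2)cc(C#N)n1` gives 35 nM, and compound 3 `CCOc1cc(NC(=O)NCc2cc(C)c(-c3cn(C)nc3C(F)(F)F)nn2)cc(C)n1` gives 242 nM, the highest of the three numbers; the step of a 6.9-fold higher number from compound 2 to compound 3 (0.84 log units; beyond the scatter) is the only one between compounds that differ in a single place. Compound 4 `CCOc1nc(Cl)cc(NC(=O)NCc2cc(C)c(-c3cn(C)nc3C(F)(F)F)nn2)c1C` differs from compound 3 in 6-chloro-2-ethoxy-3-methylpyridin-4-yl in place of 2-ethoxy-6-methylpyridin-4-yl on an amide-type nitrogen. Within the data shown here, no measured step covers a chloro on this ring or the shifted methyl, so the step from compound 2 to compound 3 bears on it only loosely, as a change on the same ring. The expectation is therefore a step of a 1.2-fold lower number from compound 3 to compound 4 (0.08 log units; within the scatter) within the scatter, with no set direction. Compound 4 is estimated at 200 nM, between 60 nM and 800 nM.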

Compound 4, half-maximal inhibitory concentration: 15 nM
The estimate for compound 4 lay 13-fold (1.12 log units) above the measured number; the measured number lies below the stated range.
By their numbers in this assay, from the lowest: compound 1; then compound 4; then compound 2; then compound 3.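

Within the data shown here, on the amide-type nitrogen, 6-chloro-2-ethoxy-3-methylpyridin-4-yl in place of 2-ethoxy-6-methylpyridin-4-yl gives a 16-fold lower number from compound 3 to compound 4 (1.21 log units; beyond the scatter) in this assay, the first step on this ring to a lower number from the methyl compound. The same group also improves on 2-cyano-6-ethoxypyridin-4-yl, with a 2.3-fold lower number from compound 2 to compound 4 (0.37 log units; beyond the scatter) as the step. No measurement here explains either step. The chloro and the moved methyl arrive together, so their separate shares remain unresolved. As far as these compounds go, whether bromo or methoxy could stand in place of the chloro also remains open.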